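Taking One Methyl off Compound 1

The source may report more compounds than this note shows. Statements on the series, on what has been measured and on what is new or still open speak of the compounds shown alone.

In a functional assay on cells (Panel renal (Carcinoma cell lines), Homo sapiens) for inhibition (on this read-out lower numbers stand for stronger inhibition of growth and higher numbers for weaker inhibition of growth), compound 1 (`Cc1ccc2c(O)cc(-c3cccc(Cl)c3)nc2n1`) gives > 100000 nM, which is a limit and not a number. Compound 2 (`Cc1cc(C)c2c(O)cc(-c3cccc(Cl)c3)nc2n1`), with one extra methyl, gives 58900 nM. Compound 3 (`Oc1cc(-c2cccc(Cl)c2)nc2ncccc12`) has hydrogen in place of methyl on an aromatic carbon. Going by the values given here, that methyl is present in both measured compounds, so the only guide is a different methyl change, an at least 1.6-fold lower number from compound 1 to compound 2 (0.22 log units; that floor lies within the scatter). No step beyond the scatter is expected, and a limit may well be reported again. The estimated step is small: an at least 1.1-fold lower number from compound 1 to compound 3 (0.04 log units; that floor lies within the scatter). For compound 3 the expected value is 90000 nM, with an estimated range from 50000 nM to 100000 nM.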

Compound 3, concentration for total growth inhibition: 49000 nM
Estimate against measurement, compound 3: 1.8-fold (0.26 log units) above; the whole stated range lies above it.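

At this position next to the ring nitrogen, hydrogen in place of methyl gives an at least 2.0-fold lower number from compound 1 to compound 3 (0.30 log units; that floor lies within the scatter). Compound 3 thus gives this position its first measured number, whereas the earlier methyl step concerned a different ring carbon. Compound 1 remains a limit, so the true size of this step cannot be read and only its floor is known: the limit of > 100000 nM in this assay, at which 1 of the 3 values shown sits.

As far as these compounds go, whether an amine, a methoxy group or a longer chain at this position would shift the number stays open. So does whether any such group would move growth inhibition beyond the usual scatter.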